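The compounds below may be only part of what the source reports. "The series", "measured", "known", "first", "only" and "open" are said of these compounds alone.

Measured so far in a functional assay on SK-MEL-2 cells (Homo sapiens) for antiproliferative activity, read by sulforhodamine B assay, with a stated time of 48 h; on this read-out higher numbers stand for weaker inhibition and lower numbers for stronger inhibition:
- Compound 1 `COc1cc(-c2nn(-c3ccc(NC(=O)c4cc(Cl)cc(Cl)c4)cc3)cc2-c2ccncc2)ccc1Cl`: > 100000 nM (a limit, not a number)
- Compound 2 `COc1cc(-c2nn(-c3ccc(NC(=O)c4ccc(Cl)c(C(F)(F)F)c4)cc3)cc2-c2ccncc2)ccc1Cl`: 3150 nM

Compound 1 stands only at a limit, > 100000 nM, and this is the limit of > 100000 nM in this assay, at which 1 of the 2 values shown sits. Compound 2 gives a true number, 3150 nM. Among the measured compounds shown here, the one measured step, an at least 31-fold lower number from compound 1 to compound 2 (1.50 log units; beyond the scatter), is large and lies beyond the scatter. It places 4-chloro-3-(trifluoromethyl)phenyl in place of 3,5-dichlorophenyl on a carbonyl carbon, and it leaves the methoxy group untouched.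

Compound 3 `O=C(Nc1ccc(-n2cc(-c3ccncc3)c(-c3ccc(Cl)c(O)c3)n2)cc1)c1cc(Cl)cc(Cl)c1` keeps that 3,5-dichlorophenyl group and changes the other end instead: hydrogen in place of methyl on an oxygen on an aromatic ring, so 4-chloro-3-methoxyphenyl becomes 4-chloro-3-hydroxyphenyl. For the measured compounds named here, no measured step covers this change. Going by the values given here, the step to compound 2, an at least 31-fold lower number from compound 1 to compound 2 (1.50 log units; beyond the scatter), shows only that a single change can bring this series to a measurable number, so it bears on the question indirectly. A lower number is therefore expected, though compound 3 may well stay at the limit. The expected size is an at least 6.6-fold lower number from compound 1 to compound 3 (0.82 log units; beyond the scatter). For compound 3 the estimated value is 15000 nM, with an expected range from 2000 nM to 100000 nM.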

Compound 3, half-maximal inhibitory concentration: 6910 nM
Estimate against measurement, compound 3: 2.2-fold (0.34 log units) above, and the stated range covers the measured number.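

In this assay, the change at this oxygen is itself enough to bring the series from the limit to a measurable number: hydrogen in place of methyl on an oxygen on an aromatic ring gives an at least 14-fold lower number from compound 1 to compound 3 (1.16 log units; beyond the scatter), a large step beyond the scatter. Among the compounds shown here, the earlier step changed only the group on the carbonyl carbon and left the methoxy group untouched, so this is the first sign that the other end of compound 1 also matters, with the 3,5-dichlorophenyl group kept in place. The full size of the step cannot be read, because compound 1 is recorded only as a limit: the limit of > 100000 nM in this assay, at which 1 of the 3 values shown sits.

The compounds shown leave open what methoxy to hydroxy does when 4-chloro-3-(trifluoromethyl)phenyl stands on the carbonyl carbon, since compound 2 and compound 3 differ in two places and their values cannot be attributed to either change alone. They also leave open how an amine or an ethoxy group on the same aromatic ring would compare with the hydroxy group of compound 3.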